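Compound 3 and the step from methoxy to hydroxy

This account rests on a few compounds, and the source may have more. Where it says the series, first, only, none or still open, it means among the compounds named here.

- compound 1 (`COc1cccc(NC(=O)c2cccc(-c3cc(=O)c4c(OC)c(OC)c(OC)cc4o3)c2)c1`): "not determined" (no result reported)
- compound 2 (`COc1ccc(NC(=O)c2cccc(-c3cc(=O)c4c(OC)c(OC)c(OC)cc4o3)c2)cc1`): "not determined" (no result reported)
- compound 3 (`COc1cc(NC(=O)c2cccc(-c3cc(=O)c4c(OC)c(OC)c(OC)cc4o3)c2)cc(OC)c1OC`): 2750 nM

Among the measured compounds shown here, in a functional assay on RAW264.7 cells (Mus musculus) for inhibition, read by Griess assay, with stated times of 1 h and 24 h (on this read-out higher numbers stand for weaker inhibition and lower numbers for stronger inhibition), compound 3 gives 2750 nM, the only number available for this small set. Compound 1 and compound 2 have no reported result, so compound 3 cannot be ranked against either of them. Its value is a single point of reference and says nothing yet about how much the structure matters.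

Compound 4 (`COc1cc(NC(=O)c2cccc(-c3cc(=O)c4c(O)c(OC)c(OC)cc4o3)c2)cc(OC)c1OC`) has not yet been measured. It departs from compound 3 in one place, hydrogen in place of methyl on an oxygen on an aromatic ring, which turns a methoxy into a hydroxy. The rest of the structure stays the same.

For the measured compounds named here, no two measured compounds differ in one place, so the data offer no step by which to size this change. The expectation is therefore tentative and carries a wide range. In this assay a modest move toward stronger inhibition is expected, estimated as a 2.3-fold lower number from compound 3 to compound 4 (0.36 log units; beyond the scatter). For compound 4 the estimated value is 1200 nM, with an expected range from 300 nM to 4500 nM.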

Compound 4, half-maximal inhibitory concentration: 2110 nM
Compound 4: the middle estimate sits 1.8-fold (0.25 log units) below what was measured, within the range that was stated.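

The step supplies the first measured size for this change, and in this assay it reads a 1.3-fold lower number from compound 3 to compound 4 (0.12 log units; within the scatter), which places the two compounds within the usual scatter of each other. At this position, on an oxygen on an aromatic ring, hydrogen can therefore stand in place of methyl without any change in inhibition that this read-out can resolve, although this rests on a single pair and cannot be extended to other positions or to other parts of the structure. Nothing shown here offers an explanation for this outcome, so the result stands as an observation only.

As far as these compounds go, whether the position would respond the same way to other groups remains open, for instance to a longer chain such as ethoxy on this oxygen, or to an amine in place of the hydroxy. Compound 1 and compound 2 have no reported result, so steps involving them cannot be read, and the contribution of the rest of the structure stays unsized.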